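Replacing methoxy on the carbonyl carbon of compound 3

A few compounds are considered here, and "the series" means these few. Any claim that something is new, unique, unknown or untested is made for them only; others in the source may bear on it.

In a functional assay on MDA-MB-435 cells (Homo sapiens) for cytotoxicity, read by MTT assay, with a stated time of 72 h (a higher number here means a weaker inhibitor, a lower number a stronger inhibitor), compound 3 `COC(=O)c1nc(Br)c2cccnc2c1N[C@H]1CC[C@H](N)CC1` gives > 20000 nM as a limit only. Compound 2 `C[C@H](NC(=O)c1nc(Br)c2cccnc2c1N[C@H]1CC[C@H](N)CC1)c1ccc(F)cc1` gives > 10000 nM as a limit too. Compound 1 `N[C@H]1CC[C@H](Nc2c(C(=O)NCc3ccc(Cl)cc3Cl)nc(Br)c3cccnc23)CC1` gives 5800 nM as a measured number. The change to compound 4 `N[C@H]1CC[C@H](Nc2c(C(=O)NCc3ccccn3)nc(Br)c3cccnc23)CC1` is ((pyridin-2-yl)methyl)amino in place of methoxy on a carbonyl carbon with ((pyridin-2-yl)methyl)amino in place of methoxy on a carbonyl carbon. Among the compounds with values here, the nearest precedent is an at least 3.4-fold higher number from compound 1 to compound 3 (0.53 log units; beyond the scatter) for the reverse kind of change, methoxy in place of (2,4-dichlorobenzyl)amino. Less encouraging, a step that the two limits leave unreadable from compound 2 to compound 3 gives no usable size, and an at least 1.7-fold higher number from compound 1 to compound 2 (0.23 log units; that floor lies within the scatter) shows that the amide-type substituent can matter. The estimated at least 2.0-fold lower number from compound 3 to compound 4 (0.30 log units; that floor lies within the scatter) is modest and points toward a lower number. For compound 4 the estimate is 10000 nM with an expected range of 4000 nM to 25000 nM in this assay here.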

Compound 4, half-maximal inhibitory concentration: 4000 nM
Estimate against measurement, compound 4: 2.5-fold (0.40 log units) above; low and high end bracket the measured number.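

In this assay, ((pyridin-2-yl)methyl)amino on the carbonyl carbon gives a clear gain over methoxy, with an at least 5.0-fold lower number from compound 3 to compound 4 (0.69 log units; beyond the scatter), so this position does not need a halogenated benzyl group to give a measured number. Among the amides there is an at least 2.5-fold lower number from compound 2 to compound 4 (0.39 log units; beyond the scatter), while a 1.5-fold lower number from compound 1 to compound 4 (0.16 log units; within the scatter) leaves pyridin-2-yl and 2,4-dichlorophenyl on the chain carbon indistinguishable. Compound 3 stands only at a limit, so its step is a floor: the limit of > 20000 nM in this assay, at which 1 of the 4 values shown sits.

From the compounds shown here alone, what a carboxylic acid on this carbonyl carbon, or a longer chain to the pyridine ring, would give in this assay remains open.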